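Acrylamide for crotonamide on the ethyl ester

The source may hold more compounds than are shown below. What is called first, only, known or untested is meant among the compounds shown, and "the series" means these compounds.

Measured compounds, a functional assay on Rec1 cells (Homo sapiens) for inhibition, read by luminescence and CellTiter-Glo, with a stated time of 72 h; a lower number here means a stronger inhibitor, a higher number a weaker inhibitor:
- compound 1 `C=CC(=O)Nc1ccc(Cn2nc(-c3ccc(Oc4ccccc4)cc3)cc2C(=O)O)cc1`: > 60000 nM
- compound 2 `C/C=C/C(=O)Nc1ccc(Cn2nc(-c3ccc(Oc4ccccc4)cc3)cc2C(=O)OCC)cc1`: 13100 nM
- compound 3 `C/C=C/C(=O)N1CCCC(n2nc(-c3ccc(Oc4ccccc4)cc3)cc2CO)C1`: 27200 nM

Compound 1 returns only a limit of this assay, (the limit of > 60000 nM in this assay, at which 1 of the 3 values shown sits), and no number. Of the two numbers shown, compound 2 has the lowest; its nearest neighbour is compound 3, whose number is higher by a step beyond the usual scatter.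

Compound 4 `C=CC(=O)Nc1ccc(Cn2nc(-c3ccc(Oc4ccccc4)cc3)cc2C(=O)OCC)cc1` is not yet measured. It differs from compound 2 in one place: vinyl in place of prop-1-en-1-yl on a carbonyl carbon. Among the measured compounds shown here, no measured pair shows this change alone, so the size of the step rests on expectation only. A small step toward a lower number is expected, probably no larger than the scatter. For compound 4 the estimate is 8000 nM, within 3000 nM to 25000 nM, which is an expected step of a 1.6-fold lower number from compound 2 to compound 4 (0.21 log units; within the scatter).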

Compound 4, half-maximal inhibitory concentration: 2800 nM
Compound 4: middle estimate off by 2.9-fold (0.46 log units), on the high side; measured number below the stated range.
By their numbers in this assay, from the lowest: compound 4; then compound 2; then compound 3. At a limit, above all of these: compound 1.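

In this assay, vinyl in place of prop-1-en-1-yl on a carbonyl carbon now has a measured size, a 4.7-fold lower number from compound 2 to compound 4 (0.67 log units; beyond the scatter). With vinyl held constant, ethyl in place of hydrogen on an oxygen next to a carbonyl group gives an at least 21-fold lower number from compound 1 to compound 4 (1.33 log units; beyond the scatter). Compound 1 gives a limit and no number: the limit of > 60000 nM in this assay, at which 1 of the 4 values shown sits.

From the compounds shown here alone, whether a saturated ethyl on the same carbonyl carbon keeps the number of compound 4 remains open. So does whether an amide or a longer alkyl ester in place of the ethyl ester moves it further.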